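The source may hold more compounds than are shown below. What is called first, only, known or untested is meant among the compounds shown, and "the series" means these compounds.

Compound 1 `CC1(C)CCC(CN2CCN(c3ccc(C(=O)NS(=O)(=O)c4ccc(NCC5CCOCC5)c([N+](=O)[O-])c4)c(Oc4cnc5[nH]ccc5c4)c3)CC2)=C(c2ccc(Cl)cc2C(F)(F)F)C1`: 74 nM
Compound 2 `CC1(C)CCC(CN2CCN(c3ccc(C(=O)NS(=O)(=O)c4ccc(NCC5CCOCC5)c([N+](=O)[O-])c4)c(Oc4cnc5[nH]ccc5c4)c3)CC2)=C(c2ccc(C(F)(F)F)cc2)C1`: 6.2 nM
Compound 3 `COc1ccc(C2=C(CN3CCN(c4ccc(C(=O)NS(=O)(=O)c5ccc(NCC6CCOCC6)c([N+](=O)[O-])c5)c(Oc5cnc6[nH]ccc6c5)c4)CC3)CCC(C)(C)C2)cc1`: 12 nM

In a functional assay on RS4-11 cells (Homo sapiens) for inhibition, read by CCK-8 assay, with a stated time of 72 h (on this read-out lower numbers stand for stronger inhibition and higher numbers for weaker inhibition), compound 3 gives 12 nM. That cannot be told apart from the value of compound 2, as a 1.9-fold higher number from compound 2 to compound 3 (0.29 log units; within the scatter) shows, but it stands clearly apart from compound 1, as a 6.2-fold lower number from compound 1 to compound 3 (0.79 log units; beyond the scatter) shows.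

Compound 4 `CC1(C)CCC(CN2CCN(c3ccc(C(=O)NS(=O)(=O)c4ccc(NCC5CCOCC5)c([N+](=O)[O-])c4)c(Oc4cnc5[nH]ccc5c4)c3)CC2)=C(c2cccc(C(F)(F)F)c2)C1` has 3-(trifluoromethyl)phenyl in place of 4-methoxyphenyl on a double-bonded ring carbon.

The closest guide is a 1.9-fold higher number from compound 2 to compound 3 (0.29 log units; within the scatter), where methoxy replaced trifluoromethyl on an aromatic carbon and the number hardly moved. The warning comes from a 12-fold lower number from compound 1 to compound 2 (1.08 log units; beyond the scatter) and from a 6.2-fold lower number from compound 1 to compound 3 (0.79 log units; beyond the scatter), which show that a change of the group on this carbon can matter. Within the data shown here, no measured compound carries the 3-(trifluoromethyl)phenyl group, so the data leave this case open and the range must stay wide.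

The expected change is small, a 1.2-fold higher number from compound 3 to compound 4 (0.07 log units; within the scatter), with no clear direction. Compound 4 is estimated at 14 nM, with an expected range from 5 nM to 40 nM.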

Compound 4, half-maximal inhibitory concentration: 63 nM
Compound 4: middle estimate off by 4.5-fold (0.65 log units), on the low side; the whole stated range lies below it.
By their numbers in this assay, from the lowest: compounds 2 and 3 (each within the scatter of the next); then compounds 4 and 1 (each within the scatter of the next).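

Moving one group is enough to change the result in this assay: with 3-(trifluoromethyl)phenyl in place of 4-(trifluoromethyl)phenyl there is a 10-fold higher number from compound 2 to compound 4 (1.01 log units; beyond the scatter), so the effect of trifluoromethyl here depends on where it sits on the aromatic ring. The earlier match between the 4-methoxyphenyl and 4-(trifluoromethyl)phenyl groups does not extend to this new group, as a 5.3-fold higher number from compound 3 to compound 4 (0.72 log units; beyond the scatter) shows, while a 1.2-fold lower number from compound 1 to compound 4 (0.07 log units; within the scatter) leaves it level with the 4-chloro-2-(trifluoromethyl)phenyl group. Nothing given here explains these differences.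

The compounds shown leave open whether a 3-methoxyphenyl group would give a similar rise, which would show if the number follows the place of substitution more than the group itself. They also leave open how a 4-aminophenyl or 4-carboxyphenyl group would behave on this carbon.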